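This account rests on a few compounds, and the source may have more. Where it says the series, first, only, none or still open, it means among the compounds named here.

Measured in an ADME assay on liver for metabolic stability, with Liver microsome (Homo sapiens) as the target, read by LC-MS, using microsomes; on this read-out higher numbers stand for fast clearance and lower numbers for slow clearance:
- compound 1 `O=C(NCc1cc(Cl)ccc1-n1cnnn1)[C@@H]1CC=NN1C(=O)[C@H](O)c1ccccc1`: < 12 mL.min-1.g-1 (a limit)
- compound 2 `CC(C)(C)C[C@@H](O)C(=O)N1C[C@@H]2C[C@@H]2[C@H]1C(=O)NCc1cc(Cl)ccc1-n1cnnn1`: 20 mL.min-1.g-1
- compound 3 `O=C(NCc1cc(Cl)ccc1-n1cnnn1)[C@@H]1[C@H]2C[C@H]2CN1C(=O)[C@H](O)Cc1ccccc1`: 96 mL.min-1.g-1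

Compound 1 stands at the limit of < 12 mL.min-1.g-1 in this assay, at which 1 of the 3 values shown sits, so its entry is a limit and not a number. Compound 4 `CCCC[C@@H](O)C(=O)N1N=CC[C@H]1C(=O)NCc1cc(Cl)ccc1-n1cnnn1` carries butyl in place of phenyl on a saturated chain carbon bound to a carbonyl carbon and an oxygen on a saturated carbon.

Within the data shown here, only one measured step bears on this. It is a 4.8-fold higher number from compound 2 to compound 3 (0.68 log units; beyond the scatter), a modest step beyond the scatter, with phenyl in place of tert-butyl. That step lies at another place on the chain, two bonds along from a carbonyl carbon and an oxygen on a saturated carbon, and it involves tert-butyl rather than butyl, so it is weak guidance. Read in reverse, it argues against a large rise in this assay on losing phenyl. Compound 2, with a saturated chain group, still gives 20 mL.min-1.g-1, so a small upward step is expected, towards faster clearance. The expected step is an at least 1.5-fold higher number from compound 1 to compound 4 (0.17 log units; that floor lies within the scatter). Compound 4 is estimated at 18 mL.min-1.g-1, with an expected range of 8 mL.min-1.g-1 to 45 mL.min-1.g-1.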

Compound 4, intrinsic clearance in microsomes in the Liver microsome assay: < 12 mL.min-1.g-1
Compound 4 ended at the assay's limit (the forecaster's own chance of this, stated with the estimate: 30%); at least 1.5-fold (0.17 log units) between middle value and limit.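

In the Liver microsome assay compound 1 gives < 12 mL.min-1.g-1, which is a limit of the assay. In the Liver microsome assay compound 4 gives < 12 mL.min-1.g-1, which is also a limit of the assay. No step can be read between these two compounds: the limit of < 12 mL.min-1.g-1 in the Liver microsome assay, at which 2 of the 4 values shown sit.

In a physicochemical assay for solubility, measured as kinetic solubility, at pH 6.8 (a higher number here means a more soluble compound, a lower number a less soluble compound), compound 1 gives 98000 nM and compound 4 gives 59000 nM. In the physicochemical assay the step is a 1.7-fold lower number from compound 1 to compound 4 (0.22 log units; within the scatter).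

What the compounds shown leave open is whether butyl in place of phenyl changes the read-out in the Liver microsome assay at all.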